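Cytotoxicity of a Diarylpyrimidine Pair and a Third Analogue

The compounds below may be only part of what the source reports. "The series", "measured", "known", "first", "only" and "open" are said of these compounds alone.

Measured compounds:
Compound 1, `Cc1cc(-c2cccc(F)c2)cc(C)c1Nc1ccnc(Nc2ccc(C#N)cc2)n1`: 4120 nM
Compound 2, `Cc1ccc(-c2cc(C)c(Nc3ccnc(Nc4ccc(C#N)cc4)n3)c(C)c2)cc1`: 5570 nM

Both compounds were tested in an ADME assay on MT4 cells (Homo sapiens) for cytotoxicity, read by MTT assay, with a stated time of 4 days; on this read-out lower numbers stand for higher toxicity in this test and higher numbers for lower toxicity in this test. Among the compounds with values here, compound 2 is one of only two measured compounds, and its number sits alongside that of compound 1: the step from compound 1 to compound 2, a 1.4-fold higher number from compound 1 to compound 2 (0.13 log units; within the scatter), is swapping one aromatic substituent for another without a change that the test can resolve.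

Compound 3, `Cc1cc(-c2c(C)cccc2C)cc(C)c1Nc1ccnc(Nc2ccc(C#N)cc2)n1`, is not yet measured. It differs from compound 2 in one place: 2,6-dimethylphenyl in place of 4-methylphenyl on an aromatic carbon. Within the data shown here, no measured step involves a 2,6-dimethylphenyl group, so nothing here speaks directly to this change. Among the measured compounds shown here, the only step available, from compound 1 to compound 2, stayed within the scatter when one aryl group replaced another at this same position. On that basis compound 3 is expected to give a number close to that of compound 2 in this assay, with no step beyond the scatter; the expected step is a 1.1-fold lower number from compound 2 to compound 3 (0.05 log units; within the scatter). The estimate for compound 3 is 5000 nM, with a range from 2500 nM to 10000 nM.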

Compound 3, half-maximal cytotoxic concentration: 2590 nM
Compound 3: the middle estimate sits 1.9-fold (0.29 log units) above what was measured; the range from low to high includes it.
By their numbers in this assay, from the lowest: compounds 3, 1 and 2 (each within the scatter of the next, the first and the last beyond it).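

In this assay, within the data shown here, the step of a 2.2-fold lower number from compound 2 to compound 3 (0.33 log units; beyond the scatter) is the first at this position to pass beyond the scatter, and it shows that the number can respond when 2,6-dimethylphenyl replaces 4-methylphenyl on this aromatic carbon, even though the change adds only one carbon and the effect is modest. The second new step, a 1.6-fold lower number from compound 1 to compound 3 (0.20 log units; within the scatter), stays within the scatter, so the same group cannot be told apart from 3-fluorophenyl in this test, and the separation holds only against 4-methylphenyl. Nothing measured alongside these numbers offers an explanation for the step between 4-methylphenyl and 2,6-dimethylphenyl.

From the compounds shown here alone, all three groups at this position are six-membered aromatic rings of carbon, so it remains open whether a single 2-methylphenyl group would give a step like the one seen with 2,6-dimethylphenyl. Going by these compounds, it is also open how the number would respond to a ring carrying an amine or a carboxylic acid, or to a non-aromatic group such as cyclohexyl at the same place.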